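Trimming the Ester Chain Down to an Acetate

The compounds below may be only part of what the source reports. "The series", "measured", "known", "first", "only" and "open" are said of these compounds alone.

Compound 1, `O=C(CCCCCc1ccccc1)OCC1COCCOCCOCCOCCOCCO1`, gives 79000 nM in a functional assay on HeLa cells (Homo sapiens) for inhibition, read by sulforhodamine B assay, with a stated time of 48 h; on this read-out lower numbers stand for stronger inhibition of growth and higher numbers for weaker inhibition of growth.
Compound 2, `O=C(CCCCCCCCCCOc1ccccc1)OCC1COCCOCCOCCOCCOCCO1`, gives 41000 nM.
Compound 3, `O=C(CCCCC1CCCCC1)OCC1COCCOCCOCCO1`, gives only a limit of > 100000 nM, the assay reporting no number for it.

Among the two numbers shown, compound 1 and compound 2 sit within the scatter of each other: a 1.9-fold lower number from compound 1 to compound 2 (0.28 log units; within the scatter). That step alters the far end of the ester chain and leaves the phenyl-bearing portion in place. Compound 4, `CC(=O)OCC1COCCOCCOCCOCCOCCO1`, differs from compound 1 in another way: hydrogen in place of 4-phenylbutyl on a saturated chain carbon bound to a carbonyl carbon. Among the compounds with values here, no measured step removes the chain itself, so the one step on record does not bear directly on it. The only pointer is that the compound with neither the aromatic ring nor the full crown reaches a limit, because of the limit of > 100000 nM in this assay, at which 1 of the 3 values shown sits. The account therefore expects a higher number for compound 4 than for compound 1, with a fair chance of a limit only: a 1.9-fold higher number from compound 1 to compound 4 (0.28 log units; within the scatter). Compound 4 is estimated at 150000 nM, spanning 50000 nM to 500000 nM.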

Compound 4, concentration for 50% growth inhibition: > 100000 nM
Compound 4: a limit, no number; the forecaster's own chance of this, stated with the estimate: 60%; the middle value is on the limit's open side.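

With 4-phenylbutyl replaced by hydrogen on the saturated chain carbon bound to a carbonyl carbon, compound 4 gives > 100000 nM in this assay, which is a limit and not a number. The step reads an at least 1.2-fold higher number from compound 1 to compound 4 (0.10 log units; that floor lies within the scatter), so only a floor is known, and that floor alone does not show a loss beyond the scatter. Compound 4 is the only compound shown that keeps the core of compound 1 and carries no aromatic ring on the ester chain, and with compound 3 it makes a second compound at the same limit: the limit of > 100000 nM in this assay, at which 2 of the 4 values shown sit.

The compounds shown leave open whether the phenyl ring or the length of the chain matters here, and a plain hexyl chain would separate the two. Also open, from the compounds shown here alone, is whether an amine or a carboxylic acid at the end of the chain would give a measurable number.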